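Triazole in place of imidazole on a shared salicylate core

A few compounds are considered here, and "the series" means these few. Any claim that something is new, unique, unknown or untested is made for them only; others in the source may bear on it.

Compound 2 `O=C(O)c1cc(-c2c[nH]cn2)ccc1O` carries a 1H-imidazol-4-yl group on the shared core. In a functional assay on the whole organism for inhibition, with Rattus norvegicus as the target, read by paw edema (on this read-out higher numbers stand for an effect only at larger amounts of compound and lower numbers for an effect already at smaller amounts), compound 2 gives 100 mg/kg, the only number measured so far among these compounds. Compound 1 `O=C(O)c1cc(-c2cncs2)ccc1O` differs from compound 2 only in bearing a 1,3-thiazol-5-yl group instead. For compound 1 the result in this assay is a limit, > 200 mg/kg, and not a number (the limit of > 200 mg/kg in this assay, at which 1 of the 2 values shown sits). The step of an at least 2.0-fold lower number from compound 1 to compound 2 (0.30 log units; that floor lies within the scatter) therefore rests on that limit, and its floor sits within the usual scatter.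

Compound 3 `O=C(O)c1cc(-n2cncn2)ccc1O` has not yet been measured. It differs from compound 2 as follows: 1H-1,2,4-triazol-1-yl in place of 1H-imidazol-4-yl on an aromatic carbon. Among the measured compounds shown here, no measured step bears directly on this change; the one step known swaps one five-membered aromatic ring for another and gave only a floor. On that basis no step beyond the scatter is expected in either direction in this assay, and compound 3 is estimated at 120 mg/kg, within a range from 50 mg/kg to 300 mg/kg, which means an expected step of a 1.2-fold higher number from compound 2 to compound 3 (0.08 log units; within the scatter).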

Compound 3, dose for half-maximal effect: 200 mg/kg
For compound 3 the middle estimate is 1.7-fold (0.22 log units) below the measured one, and the stated range covers the measured number.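

In this assay, putting 1H-1,2,4-triazol-1-yl in place of 1H-imidazol-4-yl on the aromatic carbon para to the hydroxy group and meta to the carboxy group gives a 2.0-fold higher number from compound 2 to compound 3 (0.30 log units; within the scatter), so the two compounds cannot be told apart on this read-out. Among the compounds shown here, this is the first step at this position between two actual numbers, and it shows that an exchange of one five-membered aromatic ring for another, going from 1 hydrogen-bond donor and 1 hydrogen-bond acceptor to 0 hydrogen-bond donors and 3 hydrogen-bond acceptors, comes with no step beyond the scatter here. Putting 1H-1,2,4-triazol-1-yl in place of 1,3-thiazol-5-yl gives a number no higher from compound 1 to compound 3 (the limit leaves the size open). The size of this step cannot be read, because the result for compound 1 is a limit and not a number: the limit of > 200 mg/kg in this assay, at which 1 of the 3 values shown sits.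

The compounds shown all carry a five-membered aromatic ring at this position, so they leave open what an amine, a carboxylic acid or a longer chain would give there. They also leave open whether any group at this position can bring the dose for half-maximal effect clearly below that of compound 2, 100 mg/kg.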